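Halogen removal on the N-aryl ring of compound 3

The source may hold more compounds than are shown below. What is called first, only, known or untested is meant among the compounds shown, and "the series" means these compounds.

Compound 3 `O=C(Nc1ccc(Oc2ccnc3[nH]ccc23)c(F)c1)c1nn(-c2ccc(Br)cc2)ccc1=O` sits second highest of the three numbers in a functional assay on PC-3 cells (Homo sapiens) for cytotoxicity, read by MTT assay, with a stated time of 72 h (on this read-out lower numbers stand for stronger inhibition and higher numbers for weaker inhibition), where compound 3 gives 40800 nM. For the measured compounds named here, its nearest neighbour is compound 2 `O=C(Nc1ccc(Oc2ccnc3[nH]ccc23)c(F)c1)c1nn(-c2ccc(Cl)cc2)ccc1=O`, which in this assay gives 42500 nM; the only single-point step measured, a 1.0-fold lower number from compound 2 to compound 3 (0.02 log units; within the scatter), is within the scatter. The furthest is compound 1 `O=C(Nc1ccc(Oc2ccnc3[nH]ccc23)cc1)c1nn(-c2ccccc2)ccc1=O`, which in this assay gives 15000 nM; compound 1 differs from compound 3 in two places, the halogen on the phenyl and the fluoro on the central ring, so no single step can be read from that pair.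

Compound 4 `O=C(Nc1ccc(Oc2ccnc3[nH]ccc23)c(F)c1)c1nn(-c2ccccc2)ccc1=O` is reached from compound 3 by hydrogen in place of bromo on an aromatic carbon, the group sitting para to a large group. Going by the values given here, no measured step removes a halogen from this ring; the chloro-to-bromo step from compound 2 to compound 3 says only that swapping one halogen for another leaves the number unchanged. What compound 1 shows with an unsubstituted phenyl, alongside a missing fluoro, cannot be separated into its parts. A modest move toward lower numbers is therefore expected, but not one that can be asserted beyond the scatter.

For compound 4 the estimate is 25000 nM, ranging from 10000 nM to 60000 nM, a step of a 1.6-fold lower number from compound 3 to compound 4 (0.21 log units; within the scatter) expected from compound 3 to compound 4.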

Compound 4, half-maximal inhibitory concentration: 38600 nM
Compound 4: the middle estimate sits 1.5-fold (0.19 log units) below what was measured; the range from low to high includes it.
By their numbers in this assay, from the lowest: compound 1; then compounds 4, 3 and 2 (each within the scatter of the next).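

In this assay, the change from 4-bromophenyl to phenyl gives a 1.1-fold lower number from compound 3 to compound 4 (0.02 log units; within the scatter), and the matching loss of chloro gives a 1.1-fold lower number from compound 2 to compound 4 (0.04 log units; within the scatter), so with the fluoro in place, the chloro, bromo and unsubstituted forms cannot be told apart at this position; the earlier compounds had shown this only for one halogen against another. For the compounds shown here, the gap that compound 1 showed against the halogenated compounds can now be read as a single change on the phenyl-bearing pair, a 2.6-fold higher number from compound 1 to compound 4 (0.41 log units; beyond the scatter), with fluoro in place of hydrogen on an aromatic carbon, and this is the one single-place step beyond the scatter. No measurement at hand accounts for either result.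

The compounds shown leave open whether a group other than a halogen at this position, such as an amine or a methoxy group, would move the number at all. They also leave open whether the fluoro step seen with the unsubstituted phenyl holds when bromo or chloro is present on that ring.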